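Azetidine urea series: fluorobenzamide on the aminopyridine core

The source may report more compounds than this note shows. Statements on the series, on what has been measured and on what is new or still open speak of the compounds shown alone.

Measured so far in a functional assay on A2780 cells (Homo sapiens) for antiproliferative activity, read by CellTiter-Glo, with a stated time of 72 h; a lower number here means a stronger inhibitor, a higher number a weaker inhibitor:
compound 1, `C[C@@H](c1ccc(NC(=O)N2CC(c3cccnc3)C2)cc1)N1Cc2ccccc2C1=O`, 1.5 nM
compound 2, `C[C@H](NC(=O)c1cccc(F)c1)c1ccc(NC(=O)N2CC(c3cccnc3)C2)cc1`, 2.3 nM
compound 3, `C[C@@H](c1ccc(NC(=O)N2CC(c3cncc(N)c3)C2)cc1)N1Cc2ccccc2C1=O`, 45 nM

Compound 4, `C[C@H](NC(=O)c1cccc(F)c1)c1ccc(NC(=O)N2CC(c3cncc(N)c3)C2)cc1`, is still to be measured in this assay.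

Compound 2 differs from compound 1 by a group of 10 heavy atoms (7 carbon, 1 nitrogen, 1 oxygen, 1 fluorine; one six-membered aromatic ring of carbon only) in place of a group of 10 heavy atoms (8 carbon, 1 nitrogen, 1 oxygen; one five-membered non-aromatic ring with 1 hetero atom, one six-membered aromatic ring of carbon only), on a saturated chain carbon bound to an aromatic carbon and a saturated chain carbon, and that change gave a 1.5-fold higher number from compound 1 to compound 2 (0.19 log units; within the scatter). Compound 3 differs from compound 1 by amino in place of hydrogen on an aromatic carbon, which gave a 30-fold higher number from compound 1 to compound 3 (1.48 log units; beyond the scatter). Compound 4 differs from compound 3 by a group of 10 heavy atoms (7 carbon, 1 nitrogen, 1 oxygen, 1 fluorine; one six-membered aromatic ring of carbon only) in place of a group of 10 heavy atoms (8 carbon, 1 nitrogen, 1 oxygen; one five-membered non-aromatic ring with 1 hetero atom, one six-membered aromatic ring of carbon only), on a saturated chain carbon bound to an aromatic carbon and a saturated chain carbon, at the same place as in the pair of compound 1 and compound 2, so it is the same change on the other core.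

From compound 3 to compound 4 a step of a 1.3-fold higher number from compound 3 to compound 4 (0.12 log units; within the scatter) is expected, because the same change gave a 1.5-fold higher number from compound 1 to compound 2 (0.19 log units; within the scatter). The expectation rests on one pair only. Compound 4 is therefore estimated at 60 nM, with a range from 25 nM to 150 nM expected.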

Compound 4, half-maximal inhibitory concentration: 240 nM
Compound 4: the middle estimate sits 4.0-fold (0.60 log units) below what was measured; the whole stated range lies below it.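

In this assay the swap at the saturated chain carbon does not carry over unchanged to the amino-bearing core, where it gives a 5.3-fold higher number from compound 3 to compound 4 (0.73 log units; beyond the scatter), and the comparison with the core of compound 1 shows a real gap: the same change on two cores in this assay, a 1.5-fold higher number (0.19 log units; within the scatter) from compound 1 to compound 2 and a 5.3-fold higher number (0.73 log units; beyond the scatter) from compound 3 to compound 4, 3.5-fold (0.54 log units) apart, beyond the scatter of two such steps

Read the other way, amino in place of hydrogen on an aromatic carbon gives a 100-fold higher number from compound 2 to compound 4 (2.02 log units; beyond the scatter), and this also differs from the same change made with the other group in place: the same change on two cores in this assay, a 30-fold higher number (1.48 log units; beyond the scatter) from compound 1 to compound 3 and a 100-fold higher number (2.02 log units; beyond the scatter) from compound 2 to compound 4, 3.5-fold (0.54 log units) apart, beyond the scatter of two such steps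

The two changes are therefore not independent in these compounds, but this single set of pairs does not show why, or whether it holds for other groups.

Still open, going by these compounds, is whether methyl, hydroxyl or methoxy in place of amino would give the same gap. Also open, on these data alone, is whether an unfluorinated benzoylamino group would behave like ((3-fluorophenyl)carbonyl)amino.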